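Pyridine for Phenyl on a Sulfonamide Nitrogen

The source may hold more compounds than are shown below. What is called first, only, known or untested is meant among the compounds shown, and "the series" means these compounds.

Measured so far:
compound 1 `O=S(=O)(CSc1nnc(Br)n1Cc1ccc(Br)c2ccccc12)Nc1ccccc1`: 15800 nM
compound 2 `O=S(=O)(CSc1nnc(Br)n1Cc1ccc(Br)c2ccccc12)Nc1cccnc1`: 32 nM

In an assay on HEK293 cells for inhibition of solute carrier family 22 member 12 (Homo sapiens) (a lower number here means a stronger inhibitor, a higher number a weaker inhibitor), compound 1 stands at the highest of the two numbers, the weaker inhibitor. Compound 3 `O=S(=O)(CSc1nnc(Br)n1Cc1ccc(Br)c2ccccc12)Nc1cnccc1I` differs from it in one place: 4-iodopyridin-3-yl in place of phenyl on a sulfonamide nitrogen. Among the measured compounds shown here, the one measured step that bears on this, a 490-fold lower number from compound 1 to compound 2 (2.69 log units; beyond the scatter), puts a pyridin-3-yl at the same sulfonamide nitrogen and is large. For the measured compounds named here, compound 3 carries that same pyridin-3-yl, with an iodine added; no measured pair shows what the iodine alone does, so the range is kept wide. A large step down is expected, a 320-fold lower number from compound 1 to compound 3 (2.50 log units; beyond the scatter). Compound 3 is estimated at 50 nM, between 8 nM and 400 nM.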

Compound 3, half-maximal inhibitory concentration: 10600 nM
For compound 3 the middle estimate is 210-fold (2.33 log units) below the measured one, outside the stated range (above it).
By their numbers in this assay, from the lowest: compound 2; then compounds 3 and 1 (each within the scatter of the next).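

In this assay, iodo in place of hydrogen on an aromatic carbon is a large change (a 330-fold higher number from compound 2 to compound 3 (2.52 log units; beyond the scatter)), so the strong inhibition of compound 2 does not survive this one added atom. Set against phenyl, 4-iodopyridin-3-yl gives a 1.5-fold lower number from compound 1 to compound 3 (0.17 log units; within the scatter), so the pyridine ring does not bring a gain by itself in every case. Nothing measured here explains the loss.

Still open, on these data alone, is whether fluorine, chlorine, a methyl group or an amine in place of that iodine would keep the strength of compound 2.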